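The source may hold more compounds than are shown below. What is called first, only, known or untested is meant among the compounds shown, and "the series" means these compounds.

Measured so far in a functional assay on isolated protein for agonist activity at Glucose-dependent insulinotropic receptor (Homo sapiens), read by HTRF and cAMP accumulation; a lower number here means a smaller maximal response, a higher number a larger maximal response:
compound 1, `CC(C)OC(=O)N1CCC(O[C@H]2CC[C@H](Oc3cnc(S(C)(=O)=O)cn3)CC2)CC1`: 110%
compound 2, `C[C@H](CF)OC(=O)N1CCC(O[C@H]2CC[C@H](Oc3cnc(S(C)(=O)=O)cn3)CC2)CC1`: 108%
compound 3, `CS(=O)(=O)c1cnc(O[C@H]2CC[C@H](OC3CCN(C(=O)Oc4ccccc4)CC3)CC2)cn1`: 116%

Compound 3 carries the highest number of the three, but its gaps to the others are small: a number 6 percentage points higher from compound 1 to compound 3 (within the scatter) and a number 8 percentage points higher from compound 2 to compound 3 (within the scatter), both within the scatter. The step of a number 2 percentage points lower from compound 1 to compound 2 (within the scatter) is likewise within the scatter. All three measured steps swap the group on the oxygen next to the carbonyl group and leave the maximal response in this assay essentially unchanged.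

Compound 4, `CS(=O)(=O)c1cnc(O[C@H]2CC[C@H](OC3CCN(C(=O)C4(C(F)(F)F)CCCC4)CC3)CC2)cn1`, is the next member. Its change from compound 3: a group of 9 heavy atoms (6 carbon, 3 fluorine; one five-membered non-aromatic ring of carbon only) in place of a group of 7 heavy atoms (6 carbon, 1 oxygen; one six-membered aromatic ring of carbon only), on a carbonyl carbon

Among the compounds with values here, no measured step removes the oxygen from the carbonyl carbon or puts a non-aromatic ring there, so the measured steps bear on this change only loosely. Within the data shown here, they do show that varied groups in this part of the molecule gave responses within the scatter of one another, with no compound going against that. The step of a number 8 percentage points lower from compound 3 to compound 4 (within the scatter) is therefore expected to be small, without a direction beyond the scatter. Compound 4 is expected to give about 108% in this assay, within 90% to 125%.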

Compound 4, largest response reached (Emax), in percent of the reference or control that the assay uses: 95%
Compound 4: middle estimate off by 13 percentage points, on the high side, and the stated range covers the measured number.
By their numbers in this assay, from the lowest: compound 4; then compounds 2, 1 and 3 (each within the scatter of the next).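

Across the three carbamates, the group on the carbonyl carbon made no difference beyond the scatter, but this change does register in this assay as a number 21 percentage points lower from compound 3 to compound 4 (beyond the scatter) and as a number 15 percentage points lower from compound 1 to compound 4 (beyond the scatter) and as a number 13 percentage points lower from compound 2 to compound 4 (beyond the scatter) in the listed steps. Compound 4 therefore sits apart from all three earlier compounds, which shows that the maximal response at this position is not indifferent to every group placed there, although compound 4 is the only compound shown with a carbon rather than an oxygen attached to the carbonyl carbon. No measured evidence explains this drop.

The change brings the five-membered non-aromatic ring, the trifluoromethyl group and the loss of the oxygen on the carbonyl carbon together, so the compounds shown cannot assign the step to any one of them. Open comparisons include a plain cyclopentyl or a methylcyclopentyl group on the carbonyl carbon, which would separate the trifluoromethyl group from the ring, and a phenyl group directly on the carbonyl carbon, which would separate the oxygen from the aromatic ring.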